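Swapping a pentyl chain for a furan-bearing group

The source may report more compounds than this note shows. Statements on the series, on what has been measured and on what is new or still open speak of the compounds shown alone.

Three compounds share one core and differ only in the group attached to an amide-type nitrogen next to a carbonyl. In a functional assay on HEK293T cells for agonist activity at histamine H2 receptor (Homo sapiens), read by beta-arrestin recruitment (on this read-out higher numbers stand for an effect only at larger amounts of compound and lower numbers for an effect already at smaller amounts), compound 1 `Cc1nc(N)sc1CCCN/C(N)=N/C(=O)N[C@H](C)c1ccccc1` gives 45.7 nM. Compound 2 `CCCCCCNC(=O)/N=C(\N)NCCCc1sc(N)nc1C`, carrying hexyl in that place, gives 85.1 nM in this assay. Compound 3 `CCCCCNC(=O)/N=C(\N)NCCCc1sc(N)nc1C`, carrying pentyl, gives 178 nM in this assay, the highest number of the three, so within this small set it acts only at the largest amounts. The step of a 3.9-fold higher number from compound 1 to compound 3 (0.59 log units; beyond the scatter) shows what replacing 1-phenylethyl by pentyl costs, while a 2.1-fold higher number from compound 2 to compound 3 (0.32 log units; beyond the scatter) shows a smaller shift from shortening the chain, and a 1.9-fold higher number from compound 1 to compound 2 (0.27 log units; within the scatter) stays inside the usual scatter.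

Compound 4 `Cc1nc(N)sc1CCCN/C(N)=N/C(=O)NC(C)c1ccco1` has not yet been measured. It differs from compound 3 in this way: 1-(furan-2-yl)ethyl in place of pentyl on an amide-type nitrogen. The new group resembles 1-phenylethyl in carrying an aromatic ring on a branched carbon, so this change roughly reverses what is seen in a 3.9-fold higher number from compound 1 to compound 3 (0.59 log units; beyond the scatter). Because a 3.9-fold higher number from compound 1 to compound 3 (0.59 log units; beyond the scatter) was modest and beyond the scatter, compound 4 is expected to give a lower number than compound 3. The expected step is a 2.5-fold lower number from compound 3 to compound 4 (0.41 log units; beyond the scatter). Compound 4 is therefore estimated at 70 nM in this assay, with a likely range from 25 nM to 200 nM.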

Compound 4, half-maximal effective concentration: 234 nM
Compound 4: the middle estimate sits 3.3-fold (0.52 log units) below what was measured, and the stated range ends below it.
By their numbers in this assay, from the lowest: compounds 1 and 2 (each within the scatter of the next); then compounds 3 and 4 (each within the scatter of the next).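

In this assay, among these compounds, moving from pentyl to 1-(furan-2-yl)ethyl on this amide-type nitrogen gives no step that can be told from the scatter (a 1.3-fold higher number from compound 3 to compound 4 (0.12 log units; within the scatter)), so an open chain and a five-membered aromatic ring on a branched carbon read alike here. Resemblance to 1-phenylethyl does not carry over to the furan-bearing group: the step from the phenyl-bearing compound is beyond the scatter (a 5.1-fold higher number from compound 1 to compound 4 (0.71 log units; beyond the scatter)), and so is the step from the hexyl compound (a 2.7-fold higher number from compound 2 to compound 4 (0.44 log units; beyond the scatter)), which shows that an aromatic ring on a branched carbon is not enough on its own to give a number as low as those of compound 1 and compound 2. Nothing available here explains why the two ring-bearing groups differ in this way.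

The compounds shown leave open whether 1-(thiophen-2-yl)ethyl, with sulfur in place of the ring oxygen, or furan-2-ylmethyl, without the methyl on the branched carbon, would read like the furan-bearing group or like 1-phenylethyl. They also leave open how a longer chain such as heptyl would compare with hexyl and pentyl at this nitrogen.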